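Amino for methoxy on the shared core

The source may hold more compounds than are shown below. What is called first, only, known or untested is meant among the compounds shown, and "the series" means these compounds.

Compound 1 `COc1ncnc2[nH]cc(Sc3cccs3)c12` is read in a functional assay on CEM-DNR cells (Homo sapiens), read by MTT assay, with a stated time of 3 days; a lower number here means a stronger inhibitor, a higher number a weaker inhibitor. In this assay compound 1 reaches only the assay limit, > 50000 nM. Compound 2 `CN(C)c1ncnc2[nH]cc(Sc3cccs3)c12` carries dimethylamino in place of methoxy on an aromatic carbon; in this assay compound 2 gives 35300 nM. Going by the values given here, the single measured step is bounded on one side by the limit of > 50000 nM in this assay, at which 1 of the 2 values shown sits, so its true size stays open. Compound 3 `Nc1ncnc2[nH]cc(Sc3cccs3)c12` is not yet measured. It differs from compound 1 by amino in place of methoxy on an aromatic carbon. Among the compounds with values here, the only step that bears on this change is an at least 1.4-fold lower number from compound 1 to compound 2 (0.15 log units; that floor lies within the scatter), which exchanges the same methoxy for a group attached through nitrogen and whose floor lies within the scatter. On that basis the expected step in this assay for the amino compound is none beyond the scatter, in either direction, though a larger drop cannot be ruled out from an open-ended step. For compound 3 the estimate in this assay is 40000 nM, with a range from 12000 nM to 130000 nM. The expected step is an at least 1.2-fold lower number from compound 1 to compound 3 (0.09 log units; that floor lies within the scatter), and a result reported only as a limit remains quite possible.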

Compound 3, half-maximal inhibitory concentration: 20300 nM
Compound 3: middle estimate off by 2.0-fold (0.29 log units), on the high side, within the range that was stated.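

In this assay, going by these compounds alone, amino in place of methoxy on this aromatic carbon gives an at least 2.4-fold lower number from compound 1 to compound 3 (0.39 log units; beyond the scatter), the first step that is beyond the scatter, whereas the floor of the step to the dimethylamino compound lay within it. This step is a floor and not a size, as compound 1 stands only at a limit of the assay: the limit of > 50000 nM in this assay, at which 1 of the 3 values shown sits. Between the two groups attached through nitrogen, the change from dimethylamino to amino gives a 1.7-fold lower number from compound 2 to compound 3 (0.24 log units; within the scatter), which is within the scatter, so this assay does not separate compound 2 from compound 3, and both give a numerical value where the methoxy compound reaches only the limit.

The compounds shown leave open how a methylamino group, a longer chain on the nitrogen such as ethylamino, or a cyclic amine such as morpholine would read at this place on the shared core. As far as these compounds go, it also remains open whether a hydroxyl group or a chlorine atom on this aromatic carbon would read with the methoxy compound or with the two nitrogen-linked compounds.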